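The compounds below may be only part of what the source reports. "The series", "measured", "known", "first", "only" and "open" are said of these compounds alone.

Compound 2 `C[C@@H]1CN(C(=O)c2nc(Nc3cc(C4CC4)[nH]n3)c3cc(Cl)ccc3n2)CCN1C(=O)OC(C)(C)C` is the reference point here. In a physicochemical assay, read by HPLC, in phosphate buffer, with a stated time of 2 h, at pH 7.4 (on this read-out higher numbers stand for a more stable compound and lower numbers for a less stable compound), compound 2 gives 99.1%, the highest of the three numbers shown, although the gaps to the other two compounds lie within the scatter. Compound 1 `CC(C)C(=O)OCOC(=O)N1CCN(C(=O)c2nc(Nc3cc(C4CC4)[nH]n3)c3cc(Cl)ccc3n2)C[C@H]1C` carries an ((isopropylcarbonyl)oxy)methyl on the oxygen next to the carbonyl group, and in this assay compound 1 gives 93.5%. Compound 3 `C[C@@H]1CN(C(=O)c2nc(Nc3cc(C4CC4)[nH]n3)c3cc(Cl)ccc3n2)CCN1C(=O)OCc1ccccc1` carries a benzyl on that oxygen, and in this assay compound 3 gives 97.7%. The steps of a number 5.6 percentage points higher from compound 1 to compound 2 (within the scatter) and a number 1.4 percentage points lower from compound 2 to compound 3 (within the scatter) are both within the scatter, as is a number 4.2 percentage points higher from compound 1 to compound 3 (within the scatter).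

Compound 4 `CC(OC(=O)C(C)C)OC(=O)N1CCN(C(=O)c2nc(Nc3cc(C4CC4)[nH]n3)c3cc(Cl)ccc3n2)C[C@H]1C` is not yet measured. It differs from compound 2 in one place: 1-((isopropylcarbonyl)oxy)ethyl in place of tert-butyl on an oxygen next to a carbonyl group. The closest guide is the step from compound 1 to compound 2, which exchanged a group of the same family for tert-butyl and moved only a number 5.6 percentage points higher from compound 1 to compound 2 (within the scatter); compound 4 walks that exchange back with one extra methyl on the chain. Within the data shown here, no step among the measured compounds reaches beyond the scatter, so for compound 4 no step beyond the scatter is expected either, with at most a slight downward lean. The expected value for compound 4 in this assay is 93%, between 84% and 99%, meaning an expected step of a number 6.1 percentage points lower from compound 2 to compound 4 (within the scatter).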

Compound 4, percent of the compound remaining: 96.6%
The estimate for compound 4 lay 3.6 percentage points below the measured number; the range from low to high includes it.
By their numbers in this assay, from the lowest: compounds 1, 4, 3 and 2 (each within the scatter of the next).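

The earlier compounds shown here showed this oxygen next to a carbonyl group carrying ((isopropylcarbonyl)oxy)methyl, tert-butyl or benzyl, and 1-((isopropylcarbonyl)oxy)ethyl now joins them without leaving the scatter in this assay (both a number 2.5 percentage points lower from compound 2 to compound 4 (within the scatter) and a number 1.1 percentage points lower from compound 3 to compound 4 (within the scatter) are within it). The result also isolates the smallest change so far, methyl in place of hydrogen on a saturated chain carbon bound to two oxygens next to a carbonyl group, and that single methyl has no effect that can be told from the scatter (a number 3.1 percentage points higher from compound 1 to compound 4 (within the scatter)). With all four compounds this close, the numbers give no order of stability among these groups, and no measurement here bears on why the chain behaves this way.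

Still open, going by these compounds, is how this reading would respond if the isopropyl on the chain's carbonyl gave way to a longer chain, or if an amine or a carboxylic acid were built into the chain. The compounds shown also leave open whether any of these groups would stay just as intact outside this phosphate buffer.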